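This account rests on a few compounds, and the source may have more. Where it says the series, first, only, none or still open, it means among the compounds named here.

Measured compounds:

- Compound 1, `O=C(O)CCCCCCCCn1nc(-c2ccccc2)c(-c2ccccc2)c1-c1ccccc1`: 400 nM
- Compound 2, `O=C(O)CCCCCCCCn1nc(-c2ccccc2)cc1-c1ccccc1`: > 66000 nM (a limit of the assay)
- Compound 3, `O=C(O)CCCCCCCCn1cc(-c2ccccc2)c(-c2ccccc2)n1`: 4500 nM

In a functional assay for inhibition, with Homo sapiens as the target (on this read-out higher numbers stand for weaker inhibition and lower numbers for stronger inhibition), compound 1 gives 400 nM and stands lowest of the two numbers obtained; its nearest neighbour is compound 3, which in this assay gives 4500 nM. For compound 2 this assay reports only a limit, > 66000 nM, and no number; this is the limit described by the limit of > 66000 nM in this assay, at which 1 of the 3 values shown sits.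

The two measured steps both remove a phenyl from the shared core: an at least 160-fold higher number from compound 1 to compound 2 (2.21 log units; beyond the scatter) and an 11-fold higher number from compound 1 to compound 3 (1.05 log units; beyond the scatter). Both are large, and both concern a ring substituent rather than the chain end.

Compound 4, `c1ccc(-c2nn(CCCCCCCCc3nnn[nH]3)c(-c3ccccc3)c2-c2ccccc2)cc1`, differs from compound 1 at the chain end only: 1H-tetrazol-5-yl in place of carboxy on a saturated chain carbon, eight bonds along the chain from an aromatic nitrogen. Going by the values given here, no measured step touches this part of the molecule, so the phenyl-removal steps give no direct guide to its size or direction. With the three phenyls of compound 1 retained, the expectation is a step within the usual scatter, no change at the digits printed from compound 1 to compound 4 (within the scatter), in this assay. Compound 4 is therefore estimated at 400 nM, with a range from 120 nM to 1500 nM.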

Compound 4, half-maximal inhibitory concentration: 1040 nM
Compound 4: middle estimate off by 2.6-fold (0.41 log units), on the low side; measured number inside the range.
By their numbers in this assay, from the lowest: compound 1; then compound 4; then compound 3. At a limit, above all of these: compound 2.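

In this assay, the chain end proves far less demanding than the ring substituents: 1H-tetrazol-5-yl in place of carboxy gives a 2.6-fold higher number from compound 1 to compound 4 (0.41 log units; beyond the scatter) and thus only a modest loss of inhibition. Going by these compounds alone, this is the first measured change at the chain end, and it is smaller than the smaller of the phenyl-removal steps, an 11-fold higher number from compound 1 to compound 3 (1.05 log units; beyond the scatter) in the same assay, so carboxy is not strictly required at this position when all three phenyls are retained, though this rests on a single pair. Nothing measured here gives a reason for the size or direction of this step.

The compounds shown leave open whether the same replacement would give a similar step on the two-phenyl core of compound 3, where the starting inhibition is already weaker. They also leave open how other chain ends, such as a primary amide, a methyl ester or a hydroxamic acid, would compare with carboxy and 1H-tetrazol-5-yl, and whether a shorter chain would change the picture.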